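Adding Chloro to the Nitro-Bearing Analogue

A few compounds are considered here, and "the series" means these few. Any claim that something is new, unique, unknown or untested is made for them only; others in the source may bear on it.

Compound 1, `Cc1cc(C)cc(S(=O)(=O)n2c(SCC(=O)Nc3ccccc3Cl)nc3ccc(Cl)cc32)c1`, gives 99300 nM in an ADME assay on MT4 cells (Homo sapiens) for cytotoxicity; on this read-out lower numbers stand for higher toxicity in this test and higher numbers for lower toxicity in this test.
Compound 2, `Cc1cc(C)cc(S(=O)(=O)n2c(SCC(=O)Nc3ccccc3Br)nc3ccc(Cl)cc32)c1`, gives 145000 nM in this assay.
Compound 3, `Cc1cc(C)cc(S(=O)(=O)n2c(SCC(=O)Nc3ccccc3[N+](=O)[O-])nc3ccccc32)c1`, is reported in this assay only as a limit, >= 26000 nM.

From the compounds shown here alone, compound 3 therefore stands apart from the other two: its result is a limit and not a number, namely (the limit of >= 26000 nM in this assay, at which 1 of the 3 values shown sits), so its exact position among the measured values is unknown. Compound 4, `Cc1cc(C)cc(S(=O)(=O)n2c(SCC(=O)Nc3ccccc3[N+](=O)[O-])nc3ccc(Cl)cc32)c1`, is the next compound, and it differs from compound 3 by chloro in place of hydrogen on an aromatic carbon. Within the data shown here, the only measured step, a 1.5-fold higher number from compound 1 to compound 2 (0.16 log units; within the scatter), concerns a different exchange on a different ring, so it does not test the present change and gives no guidance on its direction. What the data do offer is that compounds 1 and 2 both carry the chloro group that enters in compound 4, and both give numbers in this assay that lie close to one another. Compound 4 is thus expected to land in the same region as those two analogues. The step that the limit leaves unreadable from compound 3 to compound 4 is estimated to stay consistent with the limit reported for compound 3. Compound 4 is expected to give about 100000 nM in this assay, with a range from 40000 nM to 250000 nM.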

Compound 4, half-maximal cytotoxic concentration: > 235000 nM
Compound 4 gave a limit, no number; the forecaster's own chance of this, stated with the estimate: 35%; at least 2.3-fold (0.37 log units) between middle value and limit.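

Compound 4 is reported in this assay only as a limit, the same kind of result as compound 3, so the step from hydrogen to chloro on this aromatic carbon cannot be read: the limit of > 235000 nM in this assay, at which 1 of the 4 values shown sits.

What the result does add concerns the group on the other ring, with the chloro group held in place. Nitro in place of chloro gives an at least 2.3-fold higher number from compound 1 to compound 4 (0.37 log units; beyond the scatter), a step beyond the usual scatter, while nitro in place of bromo gives an at least 1.6-fold higher number from compound 2 to compound 4 (0.20 log units; that floor lies within the scatter), a step whose floor stays within it. Of the two halogen analogues, only compound 1 is therefore separated from compound 4 on this read-out, in the direction of lower toxicity in this test, and the comparison with compound 2 remains unresolved.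

The compounds shown leave open how far past its limit compound 4 lies, and whether chloro in place of hydrogen shifts the read-out at all in the nitro-bearing pair. They also do not tell how an amine or a carboxylic acid in place of chloro on this aromatic carbon would read in this assay.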